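From 4-fluorophenyl to 3-methoxyphenyl on a sulfonyl sulfur

The source may report more compounds than this note shows. Statements on the series, on what has been measured and on what is new or still open speak of the compounds shown alone.

Measured so far in an ADME assay on HEK293 cells (Homo sapiens) for cytotoxicity, read by resazurin assay, with a stated time of 48 h; on this read-out lower numbers stand for higher toxicity in this test and higher numbers for lower toxicity in this test:
- Compound 1 `O=S(=O)(Nc1ccc(-c2nc3ccccc3o2)cc1)c1cccc(F)c1`: > 100000 nM (a limit, not a number)
- Compound 2 `O=S(=O)(Nc1ccc(-c2nc3ccccc3o2)cc1)c1ccc(F)cc1`: > 100000 nM (a limit, not a number)

Compound 2 gives > 100000 nM in this assay, and this is a limit. It shares that position with compound 1, as the limit of > 100000 nM in this assay, at which 2 of the 2 values shown sit, shows.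

Compound 3 `COc1cccc(S(=O)(=O)Nc2ccc(-c3nc4ccccc4o3)cc2)c1` keeps the core of compound 2 but carries 3-methoxyphenyl in place of 4-fluorophenyl on a sulfonyl sulfur.

Within the data shown here, only one measured step bears on this change, the swap of 3-fluorophenyl for 4-fluorophenyl at the same place, and it is a step that the two limits leave unreadable from compound 1 to compound 2. That step offers no size to carry over, so the expectation of no step beyond the scatter rests on a step that the two limits leave unreadable from compound 1 to compound 2 alone.

In this assay, the expected change is a number no higher from compound 2 to compound 3 (the limit leaves the size open).

The estimated value for compound 3 is 100000 nM, with an expected range from 40000 nM to 150000 nM.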

Compound 3, half-maximal cytotoxic concentration: > 100000 nM
Compound 3: no number, only a limit; the forecaster's own chance of this, stated with the estimate: 80%; the middle value lies on the limit itself.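

In this assay compound 3 gives > 100000 nM, which is a limit and not a number. Among these compounds, its steps from compound 1 and from compound 2 cannot be read, so no new step emerges. The compounds shown leave open whether these groups on the sulfonyl sulfur differ at all, as all share one position: the limit of > 100000 nM in this assay, at which 3 of the 3 values shown sit.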